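This account rests on a few compounds, and the source may have more. Where it says the series, first, only, none or still open, it means among the compounds named here.

Measured so far in an ADME assay on HepG2 2.2.15 cells (Homo sapiens) for cytotoxicity; a lower number here means that less compound is tolerated, a higher number that more compound is tolerated:
- compound 1 `CCCC(=O)OCCc1c(-c2ccccc2Cl)c2cc(Cl)ccc2[nH]c1=O`: 52000 nM
- compound 2 `O=C(CCC1CCCCC1)OCCc1c(-c2ccccc2Cl)c2cc(Cl)ccc2[nH]c1=O`: 160000 nM
- compound 3 `C/C=C/C(=O)OCCc1c(-c2ccccc2Cl)c2cc(Cl)ccc2[nH]c1=O`: 30000 nM

Compound 2 stands highest of the three numbers in this assay, so it is the compound of which the cells tolerate the most. Its distance to the nearest neighbour is given by a 3.1-fold higher number from compound 1 to compound 2 (0.49 log units; beyond the scatter), and to the furthest by a 5.3-fold lower number from compound 2 to compound 3 (0.73 log units; beyond the scatter). Compound 4 `C/C=C(\C)C(=O)OCCc1c(-c2ccccc2Cl)c2cc(Cl)ccc2[nH]c1=O` shares the same core and differs from compound 2 only in the group attached to the carbonyl carbon: 1-methylprop-1-en-1-yl in place of 2-cyclohexylethyl on a carbonyl carbon. The step that bears most directly on this change is a 5.3-fold lower number from compound 2 to compound 3 (0.73 log units; beyond the scatter), since the group entering in compound 4 is the same short unsaturated chain as in compound 3 with one more carbon. The step of a 1.7-fold lower number from compound 1 to compound 3 (0.24 log units; within the scatter) shows that two small chains on that carbonyl carbon sit within the scatter of each other. A drop of similar size is therefore expected, namely a 4.2-fold lower number from compound 2 to compound 4 (0.62 log units; beyond the scatter). Compound 4 is estimated at 38000 nM, with a range from 15000 nM to 95000 nM.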

Compound 4, half-maximal cytotoxic concentration: 350000 nM
Estimate against measurement, compound 4: 9.2-fold (0.96 log units) below; the whole stated range lies below it.
By their numbers in this assay, from the lowest: compounds 3 and 1 (each within the scatter of the next); then compound 2; then compound 4.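

In this assay, the chain on this carbonyl carbon does not order the numbers by size: 1-methylprop-1-en-1-yl, with 4 heavy atoms, replaces the larger 2-cyclohexylethyl, with 8, and gives a 2.2-fold higher number from compound 2 to compound 4 (0.34 log units; beyond the scatter), so compound 4 goes against the rise seen with the larger chain of compound 2. Small chains also prove far from interchangeable here, as 1-methylprop-1-en-1-yl in place of prop-1-en-1-yl gives a 12-fold higher number from compound 3 to compound 4 (1.07 log units; beyond the scatter), the largest step in this set, and in place of propyl it gives a 6.7-fold higher number from compound 1 to compound 4 (0.83 log units; beyond the scatter). Nothing shown here explains these differences.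

As far as these compounds go, it remains open whether a saturated branched chain such as sec-butyl would stand near compound 4 or near compound 1. From the compounds shown here alone, the effect of an amine or a carboxylic acid on this chain is also open.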